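This account rests on a few compounds, and the source may have more. Where it says the series, first, only, none or still open, it means among the compounds named here.

Working notes on the series, values from a functional assay on HeLa cells (Homo sapiens) for inhibition, read by MTT assay, with a stated time of 72 h; a lower number here means a stronger inhibitor, a higher number a weaker inhibitor:

- compound 1 `O=[N+]([O-])c1ccc(-c2nnc(SCCCN3CCN(c4nc5ccccc5o4)CC3)o2)cc1`: 114000 nM
- compound 2 `Brc1ccc(-c2nnc(SCCCN3CCN(c4nc5ccccc5o4)CC3)o2)cc1`: 187000 nM
- compound 3 `O=[N+]([O-])c1ccc(-c2nnc(SCCCN3CCN(c4nc5ccccc5s4)CC3)o2)cc1`: 97800 nM

Compound 3 stands within the scatter of both compound 1 and compound 2, so the three values give no order.

The next compound is compound 4 `c1ccc(-c2nnc(SCCCN3CCN(c4nc5ccccc5s4)CC3)o2)cc1`. Its difference from compound 3 is hydrogen in place of nitro on an aromatic carbon. This is hydrogen in place of nitro on an aromatic carbon, or 4-nitrophenyl to phenyl.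

Among the compounds with values here, no measured step puts hydrogen at this place. The closest change, bromo in place of nitro on an aromatic carbon, is a 1.6-fold higher number from compound 1 to compound 2 (0.21 log units; within the scatter). The change elsewhere in the molecule, 1,3-benzothiazol-2-yl in place of 1,3-benzoxazol-2-yl, is a 1.2-fold lower number from compound 1 to compound 3 (0.07 log units; within the scatter) and bears on this step only weakly. Going by these compounds, neither measured step leaves the scatter, so no step beyond the scatter is expected in this assay, and the direction stays open.

The estimated change is a 1.2-fold higher number from compound 3 to compound 4 (0.09 log units; within the scatter).

For compound 4 the expected value is 120000 nM, with an estimated range of 60000 nM to 240000 nM.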

Compound 4, half-maximal inhibitory concentration: 229000 nM
The estimate for compound 4 lay 1.9-fold (0.28 log units) below the measured number; the measured number falls inside the stated range.
By their numbers in this assay, from the lowest: compounds 3, 1, 2 and 4 (each within the scatter of the next, the first and the last beyond it).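

In this assay, within the data shown here, the change from 4-nitrophenyl to phenyl (a 2.3-fold higher number from compound 3 to compound 4 (0.37 log units; beyond the scatter)) is the only measured step so far that lies beyond the scatter, though it is modest. Bromo in place of nitro at the same aromatic carbon (a 1.6-fold higher number from compound 1 to compound 2 (0.21 log units; within the scatter)) stayed within the scatter, but that step carries 1,3-benzoxazol-2-yl rather than 1,3-benzothiazol-2-yl on the ring amine nitrogen, so the two steps are not a direct comparison. No measurement at hand explains the step from nitro to hydrogen.

Open, going by these compounds, is whether an amine, a methoxy group or a carboxylic acid at this place on the phenyl ring would give a lower or a higher number than nitro or hydrogen. Also open, on these data alone, is whether hydrogen in place of nitro gives a similar step in the 1,3-benzoxazol-2-yl compounds.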